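A few compounds are considered here, and "the series" means these few. Any claim that something is new, unique, unknown or untested is made for them only; others in the source may bear on it.

Working notes on the series. Compound 1 `C/N=C(\S)OC[C@H]1OC(n2cnc3c(NC4CCOC4)ncnc32)[C@H](O)[C@@H]1O` gives 45 nM in an assay on DDT1 cells (Cricetulus griseus) for binding affinity to adenosine receptor A1 (Homo sapiens), read by radioligand binding; a lower number here means a stronger inhibitor, a higher number a weaker inhibitor. Compound 2 `CCCC/N=C(\S)OC[C@H]1OC(n2cnc3c(NC4CCOC4)ncnc32)[C@H](O)[C@@H]1O` gives 157 nM in this assay, the step being a 3.5-fold higher number from compound 1 to compound 2 (0.54 log units; beyond the scatter). Compound 3 `O=C(NC1CCC1)OC[C@H]1OC(n2cnc3c(NC4CCOC4)ncnc32)[C@H](O)[C@@H]1O` gives 306 nM in this assay, the highest of the three numbers: the step of a 6.8-fold higher number from compound 1 to compound 3 (0.83 log units; beyond the scatter) lies beyond the scatter, whereas a 1.9-fold higher number from compound 2 to compound 3 (0.29 log units; within the scatter) does not. Compound 4 `CN(C)C(=O)OC[C@H]1OC(n2cnc3c(NC4CCOC4)ncnc32)[C@H](O)[C@@H]1O` is not yet measured. Its change from compound 3 is dimethylamino in place of cyclobutylamino on a carbonyl carbon. Within the data shown here, no measured step alters the group on the carbonyl carbon in this way: a 3.5-fold higher number from compound 1 to compound 2 (0.54 log units; beyond the scatter) concerns propyl for hydrogen on a saturated chain carbon bound to a double-bonded nitrogen, and a 1.9-fold higher number from compound 2 to compound 3 (0.29 log units; within the scatter) combines a change of ring with a change of heteroatom and stayed within the scatter. The measured steps therefore give no direction for this change, and in this assay no step beyond the scatter is expected for compound 4, with a wide range kept. Compound 4 is estimated at 350 nM in this assay, between 120 nM and 1000 nM, meaning an expected step of a 1.1-fold higher number from compound 3 to compound 4 (0.06 log units; within the scatter).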

Compound 4, inhibition constant: 238 nM
Beside the measured number, compound 4's estimate is 1.5-fold (0.17 log units) above it, within the range that was stated.
By their numbers in this assay, from the lowest: compound 1; then compounds 2, 4 and 3 (each within the scatter of the next).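

In this assay, the step at the carbonyl carbon is a 1.3-fold lower number from compound 3 to compound 4 (0.11 log units; within the scatter), so at this position the ring and the hydrogen-bond donor of cyclobutylamino can both give way to dimethylamino without a step beyond the scatter. Among these compounds, the wider comparisons place the new carbamate with the earlier compounds in the same way: a 1.5-fold higher number from compound 2 to compound 4 (0.18 log units; within the scatter), whereas a 5.3-fold higher number from compound 1 to compound 4 (0.72 log units; beyond the scatter), which leaves compound 1 apart from compound 4 as it already stood apart from compound 3. Nothing available bears on why these numbers fall as they do.

The compounds shown leave open how methylamino, a piperidine ring or a longer chain on the carbonyl carbon would read. On these data alone, it also remains open whether any such group would bring a carbamate as low as compound 1.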